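A Methyl Branch on the Acid Chain, Tested Twice

This account rests on a few compounds, and the source may have more. Where it says the series, first, only, none or still open, it means among the compounds named here.

Three compounds from this series were measured in a functional assay on a cell-free system (Platelet, plasma, Homo sapiens) for inhibition; a lower number here means a stronger inhibitor, a higher number a weaker inhibitor. Compound 3 `O=C(O)CCN1Cc2ccc(NC(=O)c3cccc(N4CCNCC4)c3)cc2C1=O` and compound 2 `O=C(O)CCN1Cc2ccc(NC(=O)c3ccc(N4CCNCC4)cc3)cc2C1=O` are built from the same atoms joined differently; the difference between the two cores is not broken down here. In this assay compound 3 gives 2700 nM, while compound 2 gives 540 nM, the lowest of the three numbers. Compound 1 `CC(CC(=O)O)N1Cc2ccc(NC(=O)c3cccc(N4CCNCC4)c3)cc2C1=O` arises from compound 3 through the change (methyl in place of hydrogen on a saturated chain carbon bound to an amide-type nitrogen in a ring and a saturated chain carbon), and in this assay compound 1 gives 62000 nM, a step of a 23-fold higher number from compound 3 to compound 1 (1.36 log units; beyond the scatter).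

Compound 4 `CC(CC(=O)O)N1Cc2ccc(NC(=O)c3ccc(N4CCNCC4)cc3)cc2C1=O` has not yet been measured. It differs from compound 2 by methyl in place of hydrogen on a saturated chain carbon bound to an amide-type nitrogen in a ring and a saturated chain carbon, the same change, at the same place, that carries compound 3 to compound 1. Among these compounds the change occurs twice, and only one of the two is measured. The expected step from compound 2 is a 22-fold higher number from compound 2 to compound 4 (1.35 log units; beyond the scatter), which rests on the other core because the measured step there runs a 23-fold higher number from compound 3 to compound 1 (1.36 log units; beyond the scatter). Compound 4 is therefore estimated at 12000 nM, with a likely range from 3000 nM to 50000 nM.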

Compound 4, half-maximal inhibitory concentration: 3740 nM
Compound 4: middle estimate off by 3.2-fold (0.51 log units), on the high side; the range from low to high includes it.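

In this assay the methyl branch raises the number on this core as well, with a 6.9-fold higher number from compound 2 to compound 4 (0.84 log units; beyond the scatter), so the direction of the change is the same on both cores shown. The size of the step does not carry over, and the gap between the two steps is larger than the scatter alone would give: the same change on two cores in this assay, a 23-fold higher number (1.36 log units; beyond the scatter) from compound 3 to compound 1 and a 6.9-fold higher number (0.84 log units; beyond the scatter) from compound 2 to compound 4, 3.3-fold (0.52 log units) apart, beyond the scatter of two such steps. A step measured on one core therefore gave the direction on the other core but not the magnitude, and two cores cannot show how the size of the step depends on the core or which difference between the cores accounts for the gap.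

The compounds shown leave open whether the same direction would hold with an ethyl group in place of the methyl, or with a longer chain carrying the carboxylic acid. They also leave open whether a third core would give a step close to either of these two or one of a different size.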